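The source may report more compounds than this note shows. Statements on the series, on what has been measured and on what is new or still open speak of the compounds shown alone.

In a functional assay on MCF7 cells (Homo sapiens) for inhibition, read by MTT assay, with a stated time of 72 h (a higher number here means a weaker inhibitor, a lower number a stronger inhibitor), compound 1 `CC(C)n1ncc2c(C(=O)Nc3cccnc3)cccc21` gives only a limit of the assay, > 40000 nM. Compound 2 `Cc1ccc(-n2cc(CNC(=O)c3cccc4c3cnn4C(C)C)nn2)cc1C` likewise gives only a limit of the assay, > 40000 nM. Compound 2 therefore stands at the limit that both values shown share, (the limit of > 40000 nM in this assay, at which 2 of the 2 values shown sit). Compound 3 `CC(C)n1ncc2c(C(=O)NCc3cn(-c4ccc([N+](=O)[O-])cc4)nn3)cccc21` differs from compound 2 by 4-nitrophenyl in place of 3,4-dimethylphenyl on an aromatic nitrogen. Among the compounds with values here, no measured step exists to gauge this change, and two limits allow no direction to be read. Compound 3 is expected to stay near that same limit, an expected step of a number no higher from compound 2 to compound 3 (the limit leaves the size open), none beyond the scatter. The estimate for compound 3 is 40000 nM, lying between 15000 nM and 100000 nM.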

Compound 3, half-maximal inhibitory concentration: > 40000 nM
Compound 3 ended at the assay's limit; the forecaster's own chance of this, stated with the estimate: 70%; the middle value lies on the limit itself.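

Within the data shown here, compound 2 and compound 3 both stand at a limit in this assay, and no step between them can be read. The compounds shown leave open whether 4-nitrophenyl or 3,4-dimethylphenyl on the aromatic nitrogen makes any difference to inhibition.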